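Aryl sulfone series: notes toward compound 4

The source may report more compounds than this note shows. Statements on the series, on what has been measured and on what is new or still open speak of the compounds shown alone.

Three members of the series have been measured in a functional assay on DU-145 cells (Homo sapiens) for inhibition, read by trypan blue exclusion, with a stated time of 96 h; on this read-out lower numbers stand for stronger inhibition of growth and higher numbers for weaker inhibition of growth. Compound 1 `O=C(/C(=C\c1ccc(Cl)cc1)S(=O)(=O)c1ccc(Br)cc1)c1ccc(Br)cc1` gives 50000 nM in this assay, the highest number of the three. Compound 2 `COc1ccccc1/C=C(\C(=O)c1ccc(Cl)cc1)S(=O)(=O)Cc1ccc(Cl)c(Cl)c1` gives 1000 nM in this assay, and compound 3 `O=C(O)c1ccc(C(=O)/C(=C\c2ccc(Br)c([N+](=O)[O-])c2)SCc2ccc(Br)cc2)cc1` gives 1000 nM. Compound 1 therefore stands apart from both other compounds by gaps that exceed the usual scatter, which makes it the weakest growth inhibitor among the measured compounds.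

Compound 4 `COc1ccc(/C=C(\C(=O)c2ccc(Br)cc2)S(=O)(=O)c2ccc(Br)cc2)c(OC)c1` has not yet been measured. It differs from compound 1 in one place: 2,4-dimethoxyphenyl in place of 4-chlorophenyl on a double-bonded chain carbon bound to a double-bonded chain carbon. Going by the values given here, no measured pair differs in only this place, so the size of the step cannot be read from the series directly. Compound 2 also carries a methoxy group on an aromatic ring and gives 1000 nM in this assay, but it differs from compound 1 in several other places as well, so it offers only a loose hint. For compound 4 the step of a 3.3-fold lower number from compound 1 to compound 4 (0.52 log units; beyond the scatter) is expected, toward a lower number, of a size that may not clear the scatter. The estimate for compound 4 is 15000 nM, with a range from 4000 nM to 50000 nM.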

Compound 4, concentration for 50% growth inhibition: 8000 nM
Estimate against measurement, compound 4: 1.9-fold (0.27 log units) above; low and high end bracket the measured number.
By their numbers in this assay, from the lowest: compounds 2 and 3 (each within the scatter of the next); then compound 4; then compound 1.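

In this assay, going by these compounds alone, placing 2,4-dimethoxyphenyl in place of 4-chlorophenyl on a double-bonded chain carbon bound to a double-bonded chain carbon gives a 6.3-fold lower number from compound 1 to compound 4 (0.80 log units; beyond the scatter) as the first single-place step, which shows that the number responds to a change at this position. The exchange removes the chlorine and introduces both methoxy groups at once, so the step cannot be divided between the loss of one group and the gain of the others. No measurement at hand bears on the reason for this step.

From the compounds shown here alone, it remains open whether one methoxy group alone would give a comparable step, and how an amine or a carboxylic acid on this ring would compare. Also open, going by these compounds, is whether the same exchange gives a similar step on a core carrying other groups elsewhere.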